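Three Compounds Tested for Cell Toxicity, a Fourth Awaited

A few compounds are considered here, and "the series" means these few. Any claim that something is new, unique, unknown or untested is made for them only; others in the source may bear on it.

Compound 1 `CC1(COC(=O)N2CCN(c3ccc(F)cc3)CC2)CCn2cc([N+](=O)[O-])nc2O1` gives > 64000 nM in an ADME assay on MRC5 cells (Homo sapiens) for cytotoxicity, read by resazurin assay, with a stated time of 72 h (a higher number here means a weaker inhibitor, a lower number a stronger inhibitor), which is a limit of the assay rather than a number. Compound 2 `O=[N+]([O-])c1cn2c(n1)OC(CN1CCC(c3ccc(F)cc3)CC1)CC2` gives > 64000 nM in this assay, again a limit. Compound 3 `CC1(CN2CCC(c3ccc(F)cc3)CC2)CCn2cc([N+](=O)[O-])nc2O1` gives > 64000 nM in this assay, also a limit.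

From compound 3 to compound 2 the change is hydrogen in place of methyl on a saturated ring carbon. The step that the two limits leave unreadable from compound 3 to compound 2 cannot be read, because of the limit of > 64000 nM in this assay, at which 3 of the 3 values shown sit. The difference between the core of compound 1 and the core of compound 3 is not broken down here. Compound 4 `O=C(OCC1CCn2cc([N+](=O)[O-])nc2O1)N1CCN(c2ccc(F)cc2)CC1` has not yet been measured; it differs from compound 1 by hydrogen in place of methyl on a saturated ring carbon, the same change. Compound 4 is expected to show a step that the limit leaves unreadable from compound 1 to compound 4 that stays unreadable, because of the limit of > 64000 nM in this assay, at which 3 of the 3 values shown sit. Compound 4 is therefore estimated at 100000 nM, most likely reported as a limit.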

Compound 4, half-maximal inhibitory concentration: > 64000 nM
Compound 4 was reported as a limit; the forecaster's own chance of this, stated with the estimate: 85%; the middle value lies beyond the limit too.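

No new step can be read between compound 1 and compound 4, because both stop at a limit of the assay rather than a number: the limit of > 64000 nM in this assay, at which 4 of the 4 values shown sit.

The compounds shown leave open whether replacing methyl with hydrogen changes the result in this assay at all.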